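Dropping a Bromine Atom: What Compound 3 Might Show

A few compounds are considered here, and "the series" means these few. Any claim that something is new, unique, unknown or untested is made for them only; others in the source may bear on it.

Two compounds share one core and differ only in the group attached to a carbonyl carbon. Compound 1 `COc1ccc(C(=O)c2cc(C)ccc2OCC(=O)NNC(=O)c2cc3ccccc3oc2=O)cc1` carries a 4-methoxyphenyl group there, while compound 2 `Cc1ccc(OCC(=O)NNC(=O)c2cc3ccccc3oc2=O)c(C(=O)c2ccccc2Br)c1` carries a 2-bromophenyl group. In a functional assay on DLA cells (Mus musculus) for cytotoxicity, read by trypan blue exclusion, with a stated time of 48 h (a lower number here means a stronger inhibitor, a higher number a weaker inhibitor), compound 1 gives 43500 nM, and compound 2 gives 10000 nM. The swap gave a 4.4-fold lower number from compound 1 to compound 2 (0.64 log units; beyond the scatter). Among the two numbers known, compound 2 therefore stands lowest, with compound 1 as its only neighbour.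

Compound 3 `Cc1ccc(OCC(=O)NNC(=O)c2cc3ccccc3oc2=O)c(C(=O)c2ccccc2)c1` has not yet been measured. It differs from compound 2 in one place: hydrogen in place of bromo on an aromatic carbon. Among the compounds with values here, no measured step removes a bromine from an otherwise unchanged ring, so the expectation rests on the single step available. That step, a 4.4-fold lower number from compound 1 to compound 2 (0.64 log units; beyond the scatter), shows that this part of the molecule matters beyond the scatter. Compound 3 lacks both the methoxy group of compound 1 and the bromine of compound 2, so a modest weakening relative to compound 2 is expected, not a full return to the number of compound 1. For compound 3 the estimate in this assay is 20000 nM, with a range from 8000 nM to 50000 nM, which means an expected step of a 2.0-fold higher number from compound 2 to compound 3 (0.30 log units; within the scatter).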

Compound 3, half-maximal inhibitory concentration: 89100 nM
Estimate against measurement, compound 3: 4.5-fold (0.65 log units) below; measured number outside the range, above it.
By their numbers in this assay, from the lowest: compound 2; then compound 1; then compound 3.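

In this assay the single bromine atom of the 2-bromophenyl group turns out to account for much of the activity seen so far: removing it gives an 8.9-fold higher number from compound 2 to compound 3 (0.95 log units; beyond the scatter) and leaves the plain benzoyl compound as the weakest of the three. The methoxy group of compound 1 also counts, since hydrogen in its place gives a 2.0-fold higher number from compound 1 to compound 3 (0.31 log units; beyond the scatter) and so both substituted rings give lower numbers than the bare phenyl ring, something the earlier comparison of two substituted rings could not show. No measurement available here explains why this one atom makes such a difference.

As far as these compounds go, what stays open is whether bromine itself is needed, or whether a chlorine atom or a methyl group on the same carbon would give a similar number. Compound 1 and compound 2 also differ in both the group and its place on the ring, so a methoxy group on the bromine's carbon, or a bromine on the methoxy group's carbon, would be needed to separate those two influences.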